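Cytotoxicity notes: methyl added to the dimethylphenyl amide

This account rests on a few compounds, and the source may have more. Where it says the series, first, only, none or still open, it means among the compounds named here.

Measured compounds:
- compound 1, `CCN(CC)CCCOc1cc2ncnc(Nc3nc4ccc(C(=O)Nc5c(C)cccc5C)cc4s3)c2cc1OC`, 23700 nM
- compound 2, `COc1cc2c(Nc3nc4ccc(C(=O)Nc5c(C)cccc5Cl)cc4s3)ncnc2cc1OCCCN1CCC(C)CC1`, 9200 nM
- compound 3, `COc1cc2c(Nc3nc4ccc(C(=O)Nc5c(C)cccc5C)cc4s3)ncnc2cc1OCCCN1CCCCC1`, 14700 nM

All three values come from a functional assay on U-937 cells (Homo sapiens) for cytotoxicity, read by WST assay, with a stated time of 72 h; on this read-out higher numbers stand for weaker inhibition and lower numbers for stronger inhibition. Compound 3 stands second highest of the three numbers; its nearest neighbour is compound 2, and its step to compound 1, a 1.6-fold lower number from compound 1 to compound 3 (0.21 log units; within the scatter), is within the scatter, so no ordering among the three can be read from these numbers.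

Compound 4, `COc1cc2c(Nc3nc4ccc(C(=O)Nc5c(C)cc(C)cc5C)cc4s3)ncnc2cc1OCCCN1CCCCC1`, differs from compound 3 in one place: methyl in place of hydrogen on an aromatic carbon. For the measured compounds named here, no measured step touches this ring; the only step on record, from compound 1 to compound 3, concerns the amine at the end of the chain on the shared core and was itself within the scatter. Compound 2 carries chloro where compound 3 carries methyl on this same ring, and the two values differ by an amount within the scatter, which is the only hint that substitution on this ring leaves the read-out roughly where it is. The expectation for this assay is therefore no step beyond the scatter, with a 1.1-fold lower number from compound 3 to compound 4 (0.05 log units; within the scatter) as the estimated step. Compound 4 is estimated at 13000 nM, within a range of 6000 nM to 30000 nM.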

Compound 4, half-maximal inhibitory concentration: 12200 nM
Compound 4: the middle estimate sits 1.1-fold (0.03 log units) above what was measured; low and high end bracket the measured number.
By their numbers in this assay, from the lowest: compounds 2, 4, 3 and 1 (each within the scatter of the next, the first and the last beyond it).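

In this assay, for the compounds shown here, the first measured step on this aromatic ring, 2,6-dimethylphenyl to 2,4,6-trimethylphenyl on the amide, gives a 1.2-fold lower number from compound 3 to compound 4 (0.08 log units; within the scatter) and so stays within the scatter. The read-out therefore shows no response to a methyl in place of hydrogen at the carbon para to a large group and meta to two methyl groups, at least with the piperidin-1-yl chain end of compound 3 and compound 4 held constant. The reading covers this single added group of one heavy atom, with no hydrogen-bond donors or acceptors, and no measurement on hand bears on why the two numbers stay so close.

Still open, going by these compounds, is whether a different group at this same carbon, such as methoxy, a carboxylic acid, a dimethylamino group or a longer chain such as n-butyl, would move the number beyond the scatter. Also open, on these data alone, is whether the added methyl would behave the same way with another chain end, such as the diethylamino group of compound 1, or with chloro in place of one of the flanking methyl groups, as in compound 2.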